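Trifluoromethyl for methyl on the compound 1 core

The source may hold more compounds than are shown below. What is called first, only, known or untested is meant among the compounds shown, and "the series" means these compounds.

Values so far in a functional assay on HeLa cells (Homo sapiens) for inhibition (on this read-out lower numbers stand for stronger inhibition and higher numbers for weaker inhibition), are
- compound 1 `Cc1cn(/C=C/C=O)c(=O)[nH]c1=O` gives 23000 nM
- compound 2 `Nc1nc(O)c2ncn(/C=C/C=O)c2n1` gives > 100000 nM (a limit)

For the measured compounds named here, compound 1 at 23000 nM holds the only numeric value so far and serves as the reference point. Compound 2 reads > 100000 nM and this is a limit of the assay, not a number.

Compound 3 `O=C/C=C/n1cc(C(F)(F)F)c(=O)[nH]c1=O` keeps the core of compound 1 and carries trifluoromethyl in place of methyl on an aromatic carbon with the rest of the structure unchanged. Going by the values given here, no measured pair shows a single change of this kind, so the expectation has no measured step behind it. Starting from compound 1 at 23000 nM a modest move toward stronger inhibition is expected in this assay and it may well stay within the usual scatter. The step expected is a 1.5-fold lower number from compound 1 to compound 3 (0.19 log units; within the scatter) as an estimate only. For compound 3 the estimated value is 15000 nM with an expected range of 4000 nM to 60000 nM in this read-out.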

Compound 3, half-maximal inhibitory concentration: 60000 nM
For compound 3 the middle estimate is 4.0-fold (0.60 log units) below the measured one; the measured number falls inside the stated range.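

In this assay, for the compounds shown here, the aromatic carbon two atoms from the ring nitrogen proves sensitive to what it carries: trifluoromethyl in place of methyl gives a 2.6-fold higher number from compound 1 to compound 3 (0.42 log units; beyond the scatter), the only single-place change so far, and it runs toward weaker inhibition. Between the two groups read at this carbon, methyl therefore goes with the stronger inhibition, and the position cannot be treated as indifferent to substitution. Compound 3 still reads as a number, so the change weakens inhibition without reaching the end of the read-out, whereas compound 2 stands at a limit of the assay and not at a number: the limit of > 100000 nM in this assay, at which 1 of the 3 values shown sits.

A single step cannot tell whether the loss follows from the larger group or from the fluorine atoms it brings, and the data give no cause for it. As far as these compounds go, an ethyl group, a chlorine atom or an amine on the same carbon would help separate these readings, while the effect of the same change with a different group in place of the 2-formylethenyl group remains open.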